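This account rests on a few compounds, and the source may have more. Where it says the series, first, only, none or still open, it means among the compounds named here.

Working notes on the series. Among the compounds with values here, in a functional assay on BGC-823 cells (Homo sapiens) for antiproliferative activity, read by MTT assay, with a stated time of 24 h (a lower number here means a stronger inhibitor, a higher number a weaker inhibitor), compound 2 `Clc1cccc(CSc2nnc(-c3ccc4c(c3)OCCO4)n2-c2ccccc2)c1` gives 51200 nM, the highest of the three numbers so far. Compound 1 `Clc1ccccc1CSc1nnc(-c2ccc3c(c2)OCCO3)n1-c1ccccc1` gives 17400 nM in this assay, and compound 3 `Fc1ccccc1CSc1nnc(-c2ccc3c(c2)OCCO3)n1-c1ccccc1` gives 18600 nM. The measured steps are a 2.9-fold higher number from compound 1 to compound 2 (0.47 log units; beyond the scatter), a 2.8-fold lower number from compound 2 to compound 3 (0.44 log units; beyond the scatter) and a 1.1-fold higher number from compound 1 to compound 3 (0.03 log units; within the scatter). Compound 4 `Brc1cccc(CSc2nnc(-c3ccc4c(c3)OCCO4)n2-c2ccccc2)c1` differs from compound 2 by bromo in place of chloro on an aromatic carbon. Within the data shown here, the one halogen-for-halogen step measured, a 1.1-fold higher number from compound 1 to compound 3 (0.03 log units; within the scatter), lies within the scatter, so for compound 4 no step beyond the scatter is expected in this assay. Compound 4 is therefore estimated at 51000 nM, with a range from 20000 nM to 120000 nM, which means an expected step of a 1.0-fold lower number from compound 2 to compound 4 (0.00 log units; within the scatter).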

Compound 4, half-maximal inhibitory concentration: 65600 nM
Compound 4: the middle estimate sits 1.3-fold (0.11 log units) below what was measured; measured number inside the range.
By their numbers in this assay, from the lowest: compounds 1 and 3 (each within the scatter of the next); then compounds 2 and 4 (each within the scatter of the next).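

In this assay, the change from 3-chlorobenzyl to 3-bromobenzyl gives a 1.3-fold higher number from compound 2 to compound 4 (0.11 log units; within the scatter), so exchanging one halogen for another at this ring position leaves the number within the scatter. The 3-bromobenzyl group also stands apart from the 2-halobenzyl groups, with a 3.5-fold higher number from compound 3 to compound 4 (0.55 log units; beyond the scatter) and a 3.8-fold higher number from compound 1 to compound 4 (0.58 log units; beyond the scatter), so the two 3-halo compounds carry higher numbers than the two 2-halo compounds. Nothing shown accounts for this separation. Still open, on these data alone, is how an amine or a carboxylic acid in place of the bromo would read here.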